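The source may hold more compounds than are shown below. What is called first, only, known or untested is meant among the compounds shown, and "the series" means these compounds.

Measured so far in a functional assay on HepG2 cells (Homo sapiens) for antiproliferative activity, read by CCK-8 assay, with a stated time of 72 h; on this read-out lower numbers stand for stronger inhibition and higher numbers for weaker inhibition:
Compound 1 `Nc1ccccc1NC(=O)c1ccc(COc2ccc([N+](=O)[O-])cc2)cc1`: > 32000 nM
Compound 2 `COc1ccc(OCc2ccc(C(=O)Nc3ccccc3N)cc2)cc1`: 4200 nM

Compound 1 gives > 32000 nM, which is a limit of the assay and not a number. Going by the values given here, compound 2, at 4200 nM, therefore holds the only true number and is the sole reference for the next comparison.

The next compound is compound 3 `CC(C)c1ccc(OCc2ccc(C(=O)Nc3ccccc3N)cc2)cc1`, with isopropyl in place of methoxy on an aromatic carbon, para to a large group: isopropyl in place of methoxy on an aromatic carbon.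

Among the compounds with values here, only one measured step bears on this change: an at least 7.6-fold lower number from compound 1 to compound 2 (0.88 log units; beyond the scatter), which is beyond the scatter. It shows that exchanging the group at this place can shift the read-out, but its size is bounded on one side only. It also involves nitro rather than isopropyl, so it gives no direction for the new exchange. No step beyond the scatter can therefore be expected with confidence in this assay.

The estimated step is a 1.1-fold higher number from compound 2 to compound 3 (0.03 log units; within the scatter). The estimate for compound 3 is 4500 nM, with an expected range from 1500 nM to 14000 nM.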

Compound 3, half-maximal inhibitory concentration: > 32000 nM
Compound 3 was reported as a limit; the forecaster's own chance of this, stated with the estimate: 10%; middle value at least 7.1-fold (0.85 log units) away from the limit.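

In this assay, isopropyl in place of methoxy on an aromatic carbon, para to a large group, gives an at least 7.6-fold higher number from compound 2 to compound 3 (0.88 log units; beyond the scatter). The earlier readable step at this place, an at least 7.6-fold lower number from compound 1 to compound 2 (0.88 log units; beyond the scatter), ran towards a lower number, so this place now shows a change beyond the scatter in both directions, and of the three groups shown only methoxy gives a true number. Compound 1 and compound 3 are both reported as limits, so the step between them cannot be read and nitro and isopropyl cannot be ordered against each other: the limit of > 32000 nM in this assay, at which 2 of the 3 values shown sit.

On these data alone, both readable steps are bounded on one side only, so the true size of each stays open, as does whether the methoxy result depends on its oxygen or on its small size in heavy atoms. An ethoxy, a hydroxyl or an amine at this place would show whether a number close to that of compound 2, at 4200 nM, can be kept with a group other than methoxy.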